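Replacing the 4-nitrophenyl group of compound 1

A few compounds are considered here, and "the series" means these few. Any claim that something is new, unique, unknown or untested is made for them only; others in the source may bear on it.

Compound 1 `COC(=O)c1c(NCc2ccc(Cl)cc2)noc1-c1ccc([N+](=O)[O-])cc1` gives 78300 nM
Compound 2 `CCN(CC)CCNc1noc(-c2ccc([N+](=O)[O-])cc2)c1C(=O)OC` gives 69300 nM

Among the compounds with values here, in an ADME assay on J774.A1 cells (Mus musculus) for cytotoxicity, read by MTT assay, with a stated time of 48 h (on this read-out higher numbers stand for lower toxicity in this test and lower numbers for higher toxicity in this test), compound 1 stands within the scatter of compound 2, the only other compound measured so far, and neither sits apart from the other. Compound 3 `COC(=O)c1c(NCc2ccc(Cl)cc2)noc1-c1ccc(Cl)cc1Cl` has 2,4-dichlorophenyl in place of 4-nitrophenyl on an aromatic carbon, a change counted as 2,4-dichlorophenyl in place of 4-nitrophenyl on an aromatic carbon and made next to the ring oxygen. Within the data shown here, the one measured step, a 1.1-fold lower number from compound 1 to compound 2 (0.05 log units; within the scatter), lies at a different place and leaves the 4-nitrophenyl group untouched, so it bears on this change only loosely. The data show no direction for this swap, and no shift beyond the scatter is expected. The expected change is a 1.3-fold lower number from compound 1 to compound 3 (0.12 log units; within the scatter) as an estimate with wide uncertainty. For compound 3 the estimated value is 60000 nM with an expected range from 20000 nM to 150000 nM in this assay.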

Compound 3, half-maximal cytotoxic concentration: 176000 nM
Estimate against measurement, compound 3: 2.9-fold (0.47 log units) below; the whole stated range lies below it.
By their numbers in this assay, from the lowest: compounds 2 and 1 (each within the scatter of the next); then compound 3.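

In this assay the aromatic carbon next to the ring oxygen proves to be a place where the number can move: 2,4-dichlorophenyl in place of 4-nitrophenyl gives a 2.2-fold higher number from compound 1 to compound 3 (0.35 log units; beyond the scatter) and so points towards lower toxicity in this test. The earlier change, made on the saturated chain carbon, gave a 1.1-fold lower number from compound 1 to compound 2 (0.05 log units; within the scatter) and stayed inside the scatter, so this is the first step among the compounds shown that goes beyond it. Nothing measured here explains the shift.

The compounds shown leave open whether 4-chlorophenyl alone would give the same step as 2,4-dichlorophenyl, and whether an amine or a carboxylic acid on this phenyl ring would move the number either way. They also leave open whether the swap would hold with the (diethylamino)ethyl chain of compound 2 in place of the (4-chlorobenzyl)amino group.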